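A Saturated Ring Group Replaces the Sulfur Ring

This account rests on a few compounds, and the source may have more. Where it says the series, first, only, none or still open, it means among the compounds named here.

Measured in an ADME assay on microsomes from liver (Rattus norvegicus) for metabolic stability; on this read-out lower numbers stand for a shorter-lived compound and higher numbers for a longer-lived compound:
- compound 1 `CC(C)C(/C=C1\NC(=O)NC1=O)c1ccc(-c2ccc3cccc(F)c3c2)[nH]c1=O`: 1.46 h
- compound 2 `CC(C)C(CC1C(=O)NC(=O)N1C)c1ccc(-c2ccc3cccc(F)c3c2)[nH]c1=O`: < 0.0667 h, a limit of the assay
- compound 3 `CC(C)C(/C=C1\SC(=O)NC1=O)c1ccc(-c2ccc3cccc(F)c3c2)[nH]c1=O`: 2.62 h

Compound 3 stands level with compound 1, since a 1.8-fold higher number from compound 1 to compound 3 (0.25 log units; within the scatter) lies within the scatter. It stands well clear of compound 2, with an at least 39-fold higher number from compound 2 to compound 3 (1.59 log units; beyond the scatter) a large step.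

The next compound is compound 4 `CC(C)C(CC1NC(=O)NC1=O)c1ccc(-c2ccc3cccc(F)c3c2)[nH]c1=O`, and the change from compound 3 is a group of 8 heavy atoms (4 carbon, 2 nitrogen, 2 oxygen; one five-membered non-aromatic ring with 2 hetero atoms) in place of a group of 8 heavy atoms (4 carbon, 1 nitrogen, 2 oxygen, 1 sulfur; one five-membered non-aromatic ring with 2 hetero atoms), on a saturated chain carbon bound to an aromatic carbon and a saturated chain carbon. The entering group is (2,5-dioxoimidazolidin-4-yl)methyl.

For the measured compounds named here, two measured steps bear on this change. Exchanging the ring group gave only a 1.8-fold higher number from compound 1 to compound 3 (0.25 log units; within the scatter), so the ring's sulfur is not expected to matter much on its own. The larger guide is an at least 21-fold lower number from compound 1 to compound 2 (1.34 log units; beyond the scatter), because compound 2, like compound 4, lacks the double bond that compound 1 and compound 3 carry on the ring group. The group in compound 2 has one more carbon, so only part of that step is expected to carry over.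

A clear fall in this assay is expected, namely a 6.6-fold lower number from compound 3 to compound 4 (0.82 log units; beyond the scatter). Compound 4 is estimated at 0.4 h, with an expected range of 0.07 h to 2 h.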

Compound 4, half-life: 0.35 h
Beside the measured number, compound 4's estimate is 1.1-fold (0.06 log units) above it, within the range that was stated.
By their numbers in this assay, from the lowest: compound 4; then compounds 1 and 3 (each within the scatter of the next). At a limit, below all of these: compound 2.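

In this assay, the saturated (2,5-dioxoimidazolidin-4-yl)methyl group leaves a measurable half-life at this position, but a shorter one than either ring group carrying the double bond: a 4.2-fold lower number from compound 1 to compound 4 (0.62 log units; beyond the scatter) isolates the loss of that bond within the same nitrogen ring, and a 7.5-fold lower number from compound 3 to compound 4 (0.87 log units; beyond the scatter) is of similar scale. Saturation therefore does not account for all of the collapse seen with compound 2, since hydrogen in place of methyl on an amide-type nitrogen in a ring gives an at least 5.2-fold higher number from compound 2 to compound 4 (0.71 log units; beyond the scatter). That step has no upper end, as the number for compound 2 is a limit of the assay: the limit of < 0.0667 h in this assay, at which 1 of the 4 values shown sits.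

As far as these compounds go, the true size of the methyl step remains open, as does how a saturated ring with sulfur would fare. An amine or a carboxylic acid on this chain also remains untested in the compounds shown.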